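The source may hold more compounds than are shown below. What is called first, only, known or untested is meant among the compounds shown, and "the series" means these compounds.

Compound 1, `O=C(/C=C\Nc1ccc(F)cc1)c1cn(-c2ccccc2)nc1-c1ccc(Cl)cc1`: in a functional assay on PC-3 cells (Homo sapiens) for antiproliferative activity, read by MTT assay, with a stated time of 48 h (on this read-out higher numbers stand for weaker inhibition and lower numbers for stronger inhibition), compound 1 gives only the assay limit, > 50000 nM.
Compound 2, `O=C(/C=C\Nc1ccc(C(F)(F)F)cc1)c1cn(-c2ccccc2)nc1-c1ccc(Cl)cc1`: in this assay compound 2 likewise gives only the limit, > 50000 nM.
Compound 3, `COc1ccc(N/C=C\C(=O)c2cn(-c3ccccc3)nc2-c2ccc(Cl)cc2)cc1`: in this assay compound 3 gives 10700 nM.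

Compound 2 therefore stands at the limit of this assay, one of two such values among the three measured compounds, as the limit of > 50000 nM in this assay, at which 2 of the 3 values shown sit, shows; no number is known for it. Compound 4, `COc1cc(-c2nn(-c3ccccc3)cc2C(=O)/C=C\Nc2ccc(C(F)(F)F)cc2)cc(OC)c1OC`, differs from compound 2 by 3,4,5-trimethoxyphenyl in place of 4-chlorophenyl on an aromatic carbon. The measured steps concern a different place: an at least 4.6-fold lower number from compound 2 to compound 3 (0.66 log units; beyond the scatter) and an at least 4.6-fold lower number from compound 1 to compound 3 (0.66 log units; beyond the scatter) change the group on the aniline ring, while a step that the two limits leave unreadable from compound 1 to compound 2. Going by the values given here, none of them touches the aryl ring on the shared core, so no measured step bears on the change from compound 2 to compound 4. Starting from a limit, the estimate can only be loose. Compound 4 is expected to land somewhere around 30000 nM, in the range 5000 nM to 100000 nM, which would mean an estimated step of an at least 1.6-fold lower number from compound 2 to compound 4 (0.22 log units; that floor lies within the scatter).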

Compound 4, half-maximal inhibitory concentration: > 50000 nM
Compound 4 gave a limit, no number (the forecaster's own chance of this, stated with the estimate: 55%); middle value at least 1.6-fold (0.22 log units) from the limit.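

Going by these compounds alone, compound 4 gives only a limit and no number, as compound 2 does, so no step between compound 2 and compound 4 can be read: the limit of > 50000 nM in this assay, at which 3 of the 4 values shown sit. The compounds shown leave open whether 3,4,5-trimethoxyphenyl in place of 4-chlorophenyl changes the antiproliferative read-out at all.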